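The source may report more compounds than this note shows. Statements on the series, on what has been measured and on what is new or still open speak of the compounds shown alone.

Compound 1 `Cn1ccc(-c2cccc3c2CCC3c2ncc[nH]2)n1`: in a functional assay on CHO cells for agonist activity at Alpha-1A adrenergic receptor (Homo sapiens), read by FLIPR and calcium flux (a lower number here means that less compound is needed, a higher number that more compound is needed for the effect), compound 1 reaches only the assay limit, > 1300 nM.
Compound 2 `CS(=O)(=O)Nc1cccc2c1CCC2c1ncc[nH]1`: in this assay compound 2 gives 70 nM.

Compound 2 holds the only number shown; the other value is a limit (the limit of > 1300 nM in this assay, at which 1 of the 2 values shown sits). Among the compounds with values here, the single measured step, an at least 18-fold lower number from compound 1 to compound 2 (1.26 log units; beyond the scatter), is large and beyond the scatter. Compound 3 `c1cncc(-c2cccc3c2CCC3c2ncc[nH]2)c1` differs from compound 2 by pyridin-3-yl in place of methanesulfonamido on an aromatic carbon. This change runs the measured step in reverse, an aromatic heterocycle again taking the place of methanesulfonamido, as in compound 1. A large rise is therefore expected, a 21-fold higher number from compound 2 to compound 3 (1.33 log units; beyond the scatter). Compound 3 is estimated at 1500 nM, within 300 nM to 6000 nM, with a fair chance that only a limit is reported.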

Compound 3, half-maximal effective concentration: 2060 nM
Estimate against measurement, compound 3: 1.4-fold (0.14 log units) below; the measured number falls inside the stated range.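

In this assay, pyridin-3-yl in place of methanesulfonamido on this aromatic carbon gives a 29-fold higher number from compound 2 to compound 3 (1.47 log units; beyond the scatter), so the large rise is now measured as a full step. The rise is thus not confined to 1-methyl-1H-pyrazol-3-yl: across these compounds, both aromatic heterocycles stand well behind methanesulfonamido. Compound 1 carries a limit, so its step to compound 3 cannot be read: the limit of > 1300 nM in this assay, at which 1 of the 3 values shown sits.

Open, going by these compounds, is whether an amine, an acetamido group or a carboxylic acid on this carbon would keep the number of compound 2. Also open, on these data alone, is whether a saturated ring such as morpholine would behave like the aromatic heterocycles.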